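Triazolylmethyl spirooxindoles against a colon carcinoma line

The source may hold more compounds than are shown below. What is called first, only, known or untested is meant among the compounds shown, and "the series" means these compounds.

The measured compounds:
Compound 1 `N#CC1=C(N)Oc2c(N)cc3nc4ccccc4nc3c2C12C(=O)N(Cc1cnnn1-c1ccc(Cl)cc1)c1ccccc12` reaches only the limit > 50000 nM in a functional assay on HCT-116 cells (Homo sapiens) for antiproliferative activity, read by MTT assay, with a stated time of 48 h; on this read-out lower numbers stand for stronger inhibition and higher numbers for weaker inhibition.
Compound 2 `COc1ccccc1-n1nncc1CN1C(=O)C2(C(C#N)=C(N)Oc3c(N)cc4nc5ccccc5nc4c32)c2ccccc21` likewise gives only the limit > 50000 nM in this assay.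
Compound 3 `CCc1cccc(C)c1-n1nncc1CN1C(=O)C2(C(C#N)=C(N)Oc3c(N)cc4nc5ccccc5nc4c32)c2ccccc21` also gives only the limit > 50000 nM in this assay.

Compound 3 thus stands at the limit of > 50000 nM in this assay, at which 3 of the 3 values shown sit, a limit rather than a number. The steps a step that the two limits leave unreadable from compound 1 to compound 2, a step that the two limits leave unreadable from compound 1 to compound 3 and a step that the two limits leave unreadable from compound 2 to compound 3 are all unreadable, since both ends sit at that limit. Compound 4 `Cc1ccc(Cl)cc1-n1nncc1CN1C(=O)C2(C(C#N)=C(N)Oc3c(N)cc4nc5ccccc5nc4c32)c2ccccc21` differs from compound 3 by 5-chloro-2-methylphenyl in place of 2-ethyl-6-methylphenyl on an aromatic nitrogen. Going by the values given here, no measured step bears on this change in a readable way, so no direction can be taken from them; the three limits together suggest that compound 4 is expected to remain at the limit, with a number no higher from compound 3 to compound 4 (the limit leaves the size open) expected to be unreadable. Compound 4 is therefore estimated at 50000 nM, within 20000 nM to 100000 nM.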

Compound 4, half-maximal inhibitory concentration: 37200 nM
Beside the measured number, compound 4's estimate is 1.3-fold (0.13 log units) above it, within the range that was stated.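

With 5-chloro-2-methylphenyl on the aromatic nitrogen, compound 4 is the only one of the four to give a number rather than a limit in this assay, so a change at this position can bring the read-out inside the measurable range: the limit of > 50000 nM in this assay, at which 3 of the 4 values shown sit.

The steps are an at least 1.3-fold lower number from compound 3 to compound 4 (0.12 log units; that floor lies within the scatter), an at least 1.3-fold lower number from compound 2 to compound 4 (0.12 log units; that floor lies within the scatter) and an at least 1.3-fold lower number from compound 1 to compound 4 (0.12 log units; that floor lies within the scatter). Each is only a floor, so the true size of the change cannot be read.

As far as these compounds go, it remains open whether an amine or a carboxylic acid on this phenyl ring would move the read-out further, and by how much.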